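A few compounds are considered here, and "the series" means these few. Any claim that something is new, unique, unknown or untested is made for them only; others in the source may bear on it.

Measured so far:
- Compound 1, `CCCCOCCOC1CCN(c2nc(N)c3cc(OC)c(OC)cc3n2)CC1`: 1.03 nM
- Compound 2, `COc1cc2nc(N3CCC(OCCOC(C)C)CC3)nc(N)c2cc1OC`: 0.67 nM
- Compound 3, `COc1cc2nc(N3CCC(OCC(C)O)CC3)nc(N)c2cc1OC`: 3.52 nM

All three were tested in an assay on brain for displacement of a labelled ligand from Adrenergic receptor alpha-1 (Rattus norvegicus); on this read-out higher numbers stand for weaker inhibition and lower numbers for stronger inhibition. On these numbers compound 3 stands highest of the three, which here means the weakest inhibition; its nearest neighbour is compound 1 and the furthest is compound 2, and both gaps lie beyond the usual scatter.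

Compound 4, `CCOC(C)(COC1CCN(c2nc(N)c3cc(OC)c(OC)cc3n2)CC1)c1ccccc1`, has not been measured yet. It differs from compound 3 in one place: 1-ethoxy-1-phenylethyl in place of 1-hydroxyethyl on a saturated chain carbon bound to an oxygen on a saturated carbon. The hydroxyl-bearing group leaves and an ether-bearing group with a phenyl ring enters.

Going by the values given here, two measured steps bear on this. Going from an ether chain to the hydroxyl group gave a 3.4-fold higher number from compound 1 to compound 3 (0.53 log units; beyond the scatter) and a 5.3-fold higher number from compound 2 to compound 3 (0.72 log units; beyond the scatter). Both point the same way: the hydroxyl-bearing compound 3 gives the higher number. Among the compounds with values here, compound 4 moves back from the hydroxyl to an ether, so a step to a lower number is expected, of a size comparable to those two steps, though the added phenyl ring has no counterpart among the measured compounds and widens the uncertainty. The expected step is a 2.9-fold lower number from compound 3 to compound 4 (0.47 log units; beyond the scatter). For compound 4 the estimate in this assay is 1.2 nM, with a range from 0.4 nM to 4 nM.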

Compound 4, inhibition constant: 0.15 nM
Compound 4: the middle estimate sits 8.0-fold (0.90 log units) above what was measured, outside the stated range (below it).
By their numbers in this assay, from the lowest: compound 4; then compounds 2 and 1 (each within the scatter of the next); then compound 3.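

Going by these compounds alone, this place, on a saturated chain carbon bound to an oxygen on a saturated carbon, accepts a much larger group than the earlier compounds showed, and in this assay the larger group gives a clear gain: 1-ethoxy-1-phenylethyl in place of 1-hydroxyethyl gives a 23-fold lower number from compound 3 to compound 4 (1.37 log units; beyond the scatter) and is the largest step. Removing the hydroxyl group cannot be the whole story, since the new group also improves on the two ether chains that lack a ring, with a 4.5-fold lower number from compound 2 to compound 4 (0.65 log units; beyond the scatter) and with a 6.9-fold lower number from compound 1 to compound 4 (0.84 log units; beyond the scatter) as the steps from those compounds. No measurement is available that explains this gain.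

In compound 4 the phenyl ring and the ethoxy group arrive together, so the compounds shown cannot tell which of them accounts for the low number. From the compounds shown here alone, it also remains open whether a simple benzyl group, a pyridine ring or an amine at this place would give a number as low as that of compound 4 in this assay or lose the gain.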